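A few compounds are considered here, and "the series" means these few. Any claim that something is new, unique, unknown or untested is made for them only; others in the source may bear on it.

Working notes on the series, values from an ADME assay (liver) for metabolic stability, with Liver microsome (Homo sapiens) as the target, using microsomes; on this read-out lower numbers stand for a shorter-lived compound and higher numbers for a longer-lived compound:
- compound 1 `Cc1noc(C)c1-c1ccc(-c2nc(C)c([C@H](OC(C)(C)C)C(=O)O)c(-c3ccc4c(c3)CCCO4)c2C)c(F)c1` gives 1 h
- compound 2 `Cc1cc(-c2nc(C)c([C@H](OC(C)(C)C)C(=O)O)c(-c3ccc4c(c3)CCCO4)c2C)ccc1Cl` gives 0.717 h
- compound 3 `Cc1ccc(-c2nc(C)c([C@H](OC(C)(C)C)C(=O)O)c(-c3ccc4c(c3)CCCO4)c2C)cc1` gives 0.717 h

Compound 3 stands at 0.717 h in this assay, level with compound 2 at the digits given, and within the scatter of compound 1 at 1 h in the same read-out. All three values therefore sit close together.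

The next step leads to compound 4 `Cc1nc(-c2ccccc2)c(C)c(-c2ccc3c(c2)CCCO3)c1[C@H](OC(C)(C)C)C(=O)O`. The change is hydrogen in place of methyl on an aromatic carbon, so that 4-methylphenyl becomes phenyl.

Going by the values given here, one measured step bears on this directly: no change at the digits printed from compound 2 to compound 3 (within the scatter). That step ends at the same 4-methylphenyl group that is now cut back, and it stayed within the scatter. Among the compounds with values here, it is only a single step, and no measured compound yet carries the plain phenyl group, so the evidence is thin. No shift beyond the scatter is expected, and no direction can be argued from these data.

The expected size of the change, a 1.0-fold higher number from compound 3 to compound 4 (0.02 log units; within the scatter), is therefore within the usual scatter. For compound 4 the estimate is 0.75 h with an expected range from 0.45 h to 1.25 h in this read-out.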

Compound 4, half-life: 0.533 h
Compound 4: the middle estimate sits 1.4-fold (0.15 log units) above what was measured; the range from low to high includes it.
By their numbers in this assay, from the lowest: compounds 4, 2, 3 and 1 (each within the scatter of the next).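

Cutting the 4-methylphenyl group back to phenyl, with hydrogen in place of methyl para to a large group, gives in this assay a 1.3-fold lower number from compound 3 to compound 4 (0.13 log units; within the scatter). The same comparison made from the larger group, with phenyl in place of 4-chloro-3-methylphenyl, gives a 1.3-fold lower number from compound 2 to compound 4 (0.13 log units; within the scatter), so compounds 2, 3 and 4 show that neither removing the methyl alone nor removing both the chlorine and the methyl moves the half-life beyond the scatter. Unlike the step from compound 2 to compound 3, these steps reach the unsubstituted phenyl group, but no reason for this flat picture can be drawn, as nothing measured on these compounds bears on one.

The compounds shown leave open whether a group of another kind at this position, such as an amine, a carboxylic acid or a longer alkyl chain in place of the methyl, would shift the half-life beyond the scatter. They also leave open whether the same flat picture would hold with other groups on the shared core, since all of these steps were read with that core unchanged.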